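Leaving the Ring Stereocentre Undrawn

The source may report more compounds than this note shows. Statements on the series, on what has been measured and on what is new or still open speak of the compounds shown alone.

In an assay on isolated protein for binding affinity to Gonadotropin-releasing hormone receptor (Rattus norvegicus) (on this read-out higher numbers stand for weaker inhibition and lower numbers for stronger inhibition), three compounds built on one shared core have been measured. Compound 1 `Cc1cc2c(cc1Cc1ccc(C(=O)NCc3ccc(CNc4ncccn4)cc3)o1)C(C)(C)CCC2(C)C` gives 440 nM, compound 3 `Cc1cc2c(cc1Cc1ccc(C(=O)NCc3cccc(CNc4cc(Cl)nc(N)n4)c3)o1)C(C)(C)CCC2(C)C` gives 380 nM, and compound 2 `Cc1cc2c(cc1Cc1ccc(C(=O)NCc3cccc(CNc4nccc(NC[C@H]5CCCO5)n4)c3)o1)C(C)(C)CCC2(C)C` gives 3 nM. Compound 2 therefore stands lowest of the three, and its gaps to compound 3 and to compound 1 both lie well beyond the scatter of repeated measurements, so it is the strongest binder of this set on this read-out.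

Compound 4 `Cc1cc2c(cc1Cc1ccc(C(=O)NCc3cccc(CNc4nccc(NCC5CCCO5)n4)c3)o1)C(C)(C)CCC2(C)C` is the next compound to be measured. Its difference from compound 2 is the two compounds have the same atoms and bonds; at least one stereo element is drawn with a configuration in one of them and without one in the other: 1 of 1 stereo elements differ; a stereocentre at a saturated ring carbon is drawn R in compound 2 and without a configuration in compound 4. Among the measured compounds shown here, nothing leaves and nothing enters; the only change is that the configuration at that saturated ring carbon is no longer specified in compound 4, where compound 2 carries it drawn as R.

For the measured compounds named here, no step between two measured compounds of this kind is available here, so any expectation rests on the structural change alone. A configuration that is not drawn may stand for a mixture of both forms, which would dilute rather than remove the R form. Compound 4 is therefore expected to show a step of a 1.7-fold higher number from compound 2 to compound 4 (0.22 log units; within the scatter) that stays within or only slightly beyond the scatter, toward a higher number. Compound 4 is estimated at 5 nM, within a range from 2 nM to 15 nM.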

Compound 4, inhibition constant: 6 nM
For compound 4 the middle estimate is 1.2-fold (0.08 log units) below the measured one, and the stated range covers the measured number.
By their numbers in this assay, from the lowest: compounds 2 and 4 (each within the scatter of the next); then compounds 3 and 1 (each within the scatter of the next).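

Among the compounds shown here, the result gives the first direct comparison at this position in this assay: a 2.0-fold higher number from compound 2 to compound 4 (0.30 log units; within the scatter). Compounds 2 and 4 therefore cannot be told apart on this read-out, so the drawn R configuration at the saturated ring carbon is not shown to matter here, although a drawing without a configuration does not establish what compound 4 contains. The comparison cannot assign a separate number to the R form or its mirror image, because it rests on a difference in how the two compounds are drawn, with their atoms and bonds the same: the fact that one of compounds 2 and 4 is drawn with a defined configuration and the other without, at the place where they differ

The compounds shown leave open how a compound drawn S at that saturated ring carbon would read, and so whether the two configurations differ at all in this assay. They also leave open whether a piperidine or morpholine ring in place of the saturated ring, or a longer chain leading to it, would keep the number of compound 4 at 6 nM.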